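The source may hold more compounds than are shown below. What is called first, only, known or untested is meant among the compounds shown, and "the series" means these compounds.

In a functional assay on DU-145 cells (Homo sapiens) for inhibition, read by trypan blue exclusion, with a stated time of 96 h (a lower number here means a stronger inhibitor of growth, a higher number a weaker inhibitor of growth), three compounds that differ only in the group on a double-bonded chain carbon bound to a double-bonded chain carbon have been measured. Compound 1 `CSc1ccc(/C=C(\C(=O)c2ccc(Br)cc2)S(=O)(=O)Cc2ccc(F)cc2)cc1`, with 4-(methylsulfanyl)phenyl, gives 50000 nM. Compound 2 `Cc1cc(C)cc(/C=C(\C(=O)c2ccc(Br)cc2)S(=O)(=O)Cc2ccc(F)cc2)c1`, with 3,5-dimethylphenyl, gives 10000 nM. Compound 3 `Cc1ccc(/C=C(\C(=O)c2ccc(Br)cc2)S(=O)(=O)Cc2ccc(F)cc2)s1`, with 5-methylthiophen-2-yl, gives 1000 nM, the lowest number of the three and so the strongest growth inhibitor among them.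

Compound 4 `Cc1ccc(C)c(/C=C(\C(=O)c2ccc(Br)cc2)S(=O)(=O)Cc2ccc(F)cc2)c1` has 2,5-dimethylphenyl in place of 5-methylthiophen-2-yl on a double-bonded chain carbon bound to a double-bonded chain carbon. The closest guide is compound 2, which also carries a dimethylphenyl group, and the measured change is a 10-fold lower number from compound 2 to compound 3 (1.00 log units; beyond the scatter). The change a 50-fold lower number from compound 1 to compound 3 (1.70 log units; beyond the scatter) shows that this position can matter even more, while the change a 5.0-fold lower number from compound 1 to compound 2 (0.70 log units; beyond the scatter) shows that two phenyl groups can also differ. Among the measured compounds shown here, no measured compound compares the two dimethylphenyl groups directly, so the range must stay wide.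

A rise of similar or slightly smaller size is therefore expected in this assay, and the expected change is a 7.0-fold higher number from compound 3 to compound 4 (0.85 log units; beyond the scatter). The estimated value for compound 4 is 7000 nM, with an expected range of 2000 nM to 25000 nM.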

Compound 4, concentration for 50% growth inhibition: 1000 nM
For compound 4 the middle estimate is 7.0-fold (0.85 log units) above the measured one, outside the stated range (below it).
By their numbers in this assay, from the lowest: compounds 3 and 4 (each within the scatter of the next); then compound 2; then compound 1.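

In this assay, the step with 2,5-dimethylphenyl in place of 5-methylthiophen-2-yl is no change at the digits printed from compound 3 to compound 4 (within the scatter) and shows that the five-membered aromatic ring is not needed at this position, since a six-membered aromatic ring of carbon only matches it. Moving the methyl groups alone matters a great deal, with a 10-fold lower number from compound 2 to compound 4 (1.00 log units; beyond the scatter) when 2,5-dimethylphenyl replaces 3,5-dimethylphenyl, and the step from the 4-(methylsulfanyl)phenyl group is larger, with a 50-fold lower number from compound 1 to compound 4 (1.70 log units; beyond the scatter) in the same assay. No supporting data are available to explain these steps.

Every compound shown carries an aromatic ring at this place, so the effect of an amine, a carboxylic acid or a longer open chain there remains unknown. From the compounds shown here alone, whether the same order would hold with other parts of the shared core changed also remains open.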